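The source may hold more compounds than are shown below. What is called first, only, known or untested is meant among the compounds shown, and "the series" means these compounds.

Compound 3 `CCOC(=O)c1cnc(-c2ccccc2Cl)[nH]c1=O` is the ethyl ester of compound 1 `O=C(O)c1cnc(-c2ccccc2Cl)[nH]c1=O`. In a functional assay on the whole organism (strain Sprague-Dawley) for inhibition, with Rattus norvegicus as the target, with a stated time of 10 min (a lower number here means that less compound is needed, a higher number that more compound is needed for the effect), compound 1 gives 5 mg/kg, and in this assay compound 3 gives 5 mg/kg, so that no change at the digits printed from compound 1 to compound 3 (within the scatter). Compound 2 `CCOC(=O)C(=O)Nc1ccc(OCC)c(-c2ncc(C(=O)O)c(=O)[nH]2)c1`, which differs from both in several places, gives 25 mg/kg in this assay; compound 3 thus stands with compound 1 at the lowest of the three numbers. Compound 4 `CCOC(=O)c1cnc(-c2ccccc2SCC)[nH]c1=O` arises from compound 3 by ethylsulfanyl in place of chloro on an aromatic carbon. Within the data shown here, no measured step touches this group: the single step, no change at the digits printed from compound 1 to compound 3 (within the scatter), concerns the ester alone, and compound 2 changes too much at once to isolate it. Compound 4 is therefore expected to give 6 mg/kg, in a range from 2.5 mg/kg to 15 mg/kg. The expected step of a 1.2-fold higher number from compound 3 to compound 4 (0.08 log units; within the scatter) lies within the scatter.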

Compound 4, dose for 50% inhibition: > 5 mg/kg
Compound 4: no number, only a limit; the forecaster's own chance of this, stated with the estimate: 10%; the middle value does not contradict the limit.
By their numbers in this assay, from the lowest: compounds 1 and 3 (each within the scatter of the next); then compound 2.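

In this assay, ethylsulfanyl in place of chloro, on an aromatic carbon ortho to a large group, gives a number no lower from compound 3 to compound 4 (the limit leaves the size open). Compound 4 carries a limit, not a number: the limit of > 5 mg/kg in this assay, at which 1 of the 4 values shown sits. Among these compounds, the earlier step concerned the ester alone, so this is the only reading at this position, and it shows that the exchange brings no lower number.

As far as these compounds go, whether compound 4 truly differs from compound 3 beyond the scatter stays open. So does what a methoxy group or an amine would give on this carbon.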